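N-Methylation of a ring amine in a sulfonamide series

This account rests on a few compounds, and the source may have more. Where it says the series, first, only, none or still open, it means among the compounds named here.

Of the compounds shown here, three have been measured in an assay on isolated protein for displacement of a labelled ligand from 5-hydroxytryptamine receptor 6 (Homo sapiens), read by radioligand binding; on this read-out higher numbers stand for weaker inhibition and lower numbers for stronger inhibition. Compound 1 `CCCCc1ccc(S(=O)(=O)Nc2ccc3c(c2)CCNCC3)cc1` gives 2 nM in this assay, the lowest number of the three: compound 3 `COc1cc2c(cc1NS(=O)(=O)c1ccc(-c3ccc(Cl)cc3)cc1)CCN(C)CC2` gives 10 nM, and compound 2 `Cc1cc2c(cc1NS(=O)(=O)c1ccc(-c3ccc(Cl)cc3)cc1)CCN(C)CC2` gives 15.9 nM, so compound 1 stands apart from both beyond the scatter. For the measured compounds named here, the only step between measured compounds that differ in a single place, a 1.6-fold lower number from compound 2 to compound 3 (0.20 log units; within the scatter), concerns a methoxy in place of a methyl on an aromatic carbon and lies within the scatter.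

Compound 4 `CCCCc1ccc(S(=O)(=O)Nc2ccc3c(c2)CCN(C)CC3)cc1` is not yet measured. It differs from compound 1 by methyl in place of hydrogen on an amine nitrogen in a ring. Going by the values given here, no measured pair isolates this change: compound 2 and compound 3 both carry a methyl on that ring nitrogen, but they also differ from compound 1 in other places, so their values alone cannot be read as the effect of the methyl. Among the compounds with values here, with no bearing step available, the expectation is that the methyl brings no shift beyond the scatter, and compound 4 is estimated at 3 nM, between 1 nM and 10 nM, which corresponds to an expected step of a 1.5-fold higher number from compound 1 to compound 4 (0.18 log units; within the scatter).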

Compound 4, inhibition constant: 1.26 nM
Compound 4: middle estimate off by 2.4-fold (0.38 log units), on the high side; low and high end bracket the measured number.
By their numbers in this assay, from the lowest: compounds 4 and 1 (each within the scatter of the next); then compounds 3 and 2 (each within the scatter of the next).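

For the compounds shown here, compound 1 and compound 4 form the first pair that isolates methyl in place of hydrogen on an amine nitrogen in a ring, and in this assay the step is a 1.6-fold lower number from compound 1 to compound 4 (0.20 log units; within the scatter). On the core of compound 1, then, this nitrogen carries either a hydrogen or a methyl with no difference that can be told from the scatter, and both compounds keep values in the low range of the series. No measurement shown here offers an explanation for this result, or links it to any property of the methyl.

From the compounds shown here alone, what remains open is whether the same holds for larger groups at this nitrogen, such as an ethyl, a benzyl or an acetyl, since a single methyl says nothing about how much more this place accepts. Also open is whether the methyl would behave the same way on the cores of compound 2 and compound 3, where no partner with a hydrogen on that nitrogen is shown, and how it reads on any other receptor.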